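The compounds below may be only part of what the source reports. "The series", "measured", "known", "first", "only" and "open" are said of these compounds alone.

Working notes on the series around the shared core of compound 1 `Nc1scc(CN2CCN(c3ccc(Cl)cc3Cl)CC2)c1C(=O)c1ccc(Cl)cc1`, compound 2 `Nc1scc(CN2CCN(c3ccncc3)CC2)c1C(=O)c1ccc(Cl)cc1` and compound 3 `Nc1scc(CN2CCN(c3cccc4ccccc34)CC2)c1C(=O)c1ccc(Cl)cc1`. In a functional assay on CHO cells with adenosine receptor A1 (Homo sapiens) as the target, read by cAMP accumulation and immunoassay, with a stated time of 6 min, tested at 0.1 uM (a lower number here means a stronger effect, a higher number a weaker effect of the compound at the concentration tested), compound 1 gives -11%, compound 2 gives 1.4% and compound 3 gives 0%. Compound 3 thus stands second highest of the three numbers, with compound 2 nearest, within the scatter, and compound 1 furthest, beyond the scatter.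

All three differ only in the group on the amine nitrogen in the ring. The measured steps there were a number 12.4 percentage points higher from compound 1 to compound 2 (beyond the scatter), a number 11 percentage points higher from compound 1 to compound 3 (beyond the scatter) and a number 1.4 percentage points lower from compound 2 to compound 3 (within the scatter): two modest rises from compound 1 and one flat step between compound 2 and compound 3.

Within the data shown here, compound 4 `Nc1scc(CN2CCN(CCCc3ccc(Cl)cc3)CC2)c1C(=O)c1ccc(Cl)cc1` is not yet measured. 3-(4-chlorophenyl)propyl in place of naphthalen-1-yl on an amine nitrogen in a ring No measured step exchanges an aromatic group for a chain-linked one at this place, so the bearing steps only show that changes here have been modest or within the scatter. In this assay a step of a number 1 percentage points lower from compound 3 to compound 4 (within the scatter) is expected, within the scatter. Compound 4 is estimated at -1%, range -13% to 11%.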

Compound 4, a percentage reported as activity, at one concentration (the size of the read-out at that concentration, not a potency): -3%
The estimate for compound 4 lay 2 percentage points above the measured number, within the range that was stated.
By their numbers in this assay, from the lowest: compounds 1, 4, 3 and 2 (each within the scatter of the next, the first and the last beyond it).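

In this assay, a chain-linked group at this place, 3-(4-chlorophenyl)propyl, gives a number 3 percentage points lower from compound 3 to compound 4 (within the scatter), a number 4.4 percentage points lower from compound 2 to compound 4 (within the scatter) and a number 8 percentage points higher from compound 1 to compound 4 (within the scatter). Unlike the earlier exchanges, which separated compound 1 from compound 2 and compound 3, this one leaves compound 4 within the scatter of all three, so neither the propyl link nor one six-membered aromatic ring in place of two separates it from the others at this concentration. Nothing measured on these compounds offers an explanation for this outcome.

Still open, going by these compounds, is whether a longer chain, or an amine or a carboxylic acid at the end of the chain in place of the 4-chlorophenyl, would move the read-out beyond the scatter. A read-out at a single concentration also leaves the potency of all four compounds open.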